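Swapping a Sulfur Substituent on a Saturated Amide Core

The compounds below may be only part of what the source reports. "The series", "measured", "known", "first", "only" and "open" are said of these compounds alone.

Three compounds have been measured in a functional assay on HeLa cells (Homo sapiens) for inhibition, read by CCK-8 assay, with a stated time of 72 h, tested at 8 uM; on this read-out higher numbers stand for more inhibition of growth at the one concentration tested and lower numbers for less inhibition of growth:

Compound 1, `Nc1ccccc1NC(=O)/C=C/c1ccc(CSc2ccc(F)cc2)cc1`, gives 10.4%.
Compound 2, `Nc1ccccc1NC(=O)/C=C/c1ccc(CSCCc2ccccc2)cc1`, gives 3.57%.
Compound 3, `Nc1ccccc1NC(=O)c1ccc(CSCCc2ccccc2)cc1`, gives 74.8%.

Compounds 1 and 2 share a core and differ in one place: 4-fluorophenyl in place of phenethyl on a sulfur. That change made a step of a number 6.8 percentage points higher from compound 2 to compound 1 (within the scatter), so on this pair the swap changed little. Compound 3 stands apart: in this assay it gives the highest number of the three, with its nearest neighbour, compound 1, well below it. The difference between the core of compound 3 and the core of compound 2 is not broken down here.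

The unmeasured compound 4, `Nc1ccccc1NC(=O)c1ccc(CSc2ccc(F)cc2)cc1`, takes compound 3 and applies the same change seen between compound 2 and compound 1: 4-fluorophenyl in place of phenethyl on a sulfur. The surroundings of the change are the same in both pairs, so it is the same change. Since that change gave only a number 6.8 percentage points higher from compound 2 to compound 1 (within the scatter) on the other core, a similarly small step is expected here, resting on a single prior pair, so the expectation is loose. The expected step is a number 1.2 percentage points higher from compound 3 to compound 4 (within the scatter), estimated from compound 3. In this assay compound 4 is estimated to give 76%, expected to lie between 45% and 95%.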

Compound 4, percent growth inhibition at one concentration: 79.3%
Compound 4: the middle estimate sits 3.3 percentage points below what was measured; measured number inside the range.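

On the core of compound 3, placing 4-fluorophenyl where phenethyl sat on a sulfur gave, in this assay, a number 4.5 percentage points higher from compound 3 to compound 4 (within the scatter), so the swap again left the read-out about where it was. Set side by side, the two steps agree, and in these four compounds the change carries from one core to the other with no visible difference in its size: the same change on two cores in this assay, a number 6.8 percentage points higher (within the scatter) from compound 2 to compound 1 and a number 4.5 percentage points higher (within the scatter) from compound 3 to compound 4, 2.3 percentage points apart, within the scatter of two such steps This rests on just two pairs, each tested at a single concentration, and since neither step rises above the scatter, the agreement shows only that the swap made little difference on both cores; it does not show that the swap has a real effect of its own, or that it would behave the same way on any further core.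

The compounds shown leave open whether the group on the sulfur matters at all when it is something quite different from these two aromatic groups, such as a carboxylic acid, an amine or a short methyl group. They also leave open which groups on the sulfur, if any, would move the number on either core by more than the scatter.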